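This account rests on a few compounds, and the source may have more. Where it says the series, first, only, none or still open, it means among the compounds named here.

Measured compounds:
- compound 1, `COC(=O)c1c(C)[n+]([O-])c2cc(C)c(C)cc2[n+]1[O-]` — in an ADME assay on Vero cells (Chlorocebus sabaeus) for cytotoxicity (a lower number here means a stronger inhibitor, a higher number a weaker inhibitor), compound 1 gives > 62.5 ug/mL, which is a limit of the assay and not a number.
- compound 2, `COC(=O)c1c(C)[n+]([O-])c2cc(Cl)c(Cl)cc2[n+]1[O-]` — in this assay compound 2 gives 1.68 ug/mL.

Among the compounds with values here, compound 2 is thus the only compound of the pair with a measured number; the other value sits at the limit of > 62.5 ug/mL in this assay, at which 1 of the 2 values shown sits. Since no step between two measured compounds is shown, the pair offers no measured size of change to lean on, only that compound 1 did not reach a number while compound 2 did.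

The unmeasured compound 3, `CCc1c(C(=O)OC)[n+]([O-])c2cc(Cl)c(Cl)cc2[n+]1[O-]`, differs from compound 2 in a single place: methyl in place of hydrogen on a saturated chain carbon bound to an aromatic carbon; seen one bond further out, the change reads methyl to ethyl. Both keep the dichloro-substituted core and the methyl ester of compound 2.

Within the data shown here, for a change of this small size, no step in this assay beyond the usual scatter is expected, in either direction. Compound 3 is therefore expected to give 2 ug/mL, within 0.7 ug/mL to 6 ug/mL, meaning an estimated step of a 1.2-fold higher number from compound 2 to compound 3 (0.08 log units; within the scatter).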

Compound 3, half-maximal inhibitory concentration: 4 ug/mL
Compound 3: middle estimate off by 2.0-fold (0.30 log units), on the low side; the measured number falls inside the stated range.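

In this assay, the change from methyl to ethyl on a saturated chain carbon bound to an aromatic carbon gives a 2.4-fold higher number from compound 2 to compound 3 (0.38 log units; beyond the scatter), so this place responds to even one added carbon, and the higher number means a weaker inhibitor. The earlier pair could not show this: its two compounds differ in more than one place and only one of them gave a number, whereas compound 2 and compound 3 share the dichloro-substituted core and the methyl ester and differ only in this chain. The step is modest, and nothing at hand gives a measured reason for it.

From the compounds shown here alone, whether the number keeps rising with a longer chain such as propyl, or moves differently with a cyclopropyl ring or an amine at this place, remains open. Going by these compounds, it is also open whether the same change would produce a step on the core of compound 1, whose result is a limit and not a number.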